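The source may hold more compounds than are shown below. What is called first, only, known or untested is meant among the compounds shown, and "the series" means these compounds.

Measured so far:
compound 1 `C/C=C/C(=O)CC1c2cc(OCc3cc(C)cc(C)c3)c(OCc3cc(C)cc(C)c3)cc2CCN1C(=O)OC(C)(C)C` — > 20000 nM
compound 2 `CCC[C@@H]1C[C@H](O)C/C=C(/CC)[C@H]2c3cc(OCc4ccccc4)c(OCc4ccccc4)cc3CCN12` — > 20000 nM
compound 3 `CCC[C@@H]1C[C@@H](O)/C=C\C(CC)[C@H]2c3cc(OCc4ccccc4)c(OCc4ccccc4)cc3CCN12` — 2720 nM

In a functional assay on MDA-MB-231 cells (Homo sapiens) for inhibition, read by MTT assay, with a stated time of 24 h (a higher number here means a weaker inhibitor, a lower number a stronger inhibitor), compound 1 gives > 20000 nM, which is a limit of the assay rather than a number. Compound 2 likewise gives only a limit, > 20000 nM. Compound 3 gives 2720 nM. Compound 1 thus stands at the limit of > 20000 nM in this assay, at which 2 of the 3 values shown sit, with no measured number of its own. Compound 4 `Cc1cc(C)cc(COc2cc3c(cc2OCc2cc(C)cc(C)c2)CN(C(=O)OC(C)(C)C)CC3)c1` differs from compound 1 by hydrogen in place of ((prop-1-en-1-yl)carbonyl)methyl on a saturated ring carbon. Among the compounds with values here, no measured pair in this set isolates that change, so the size of the step is open. Since compound 1 sits at the limit > 20000 nM, compound 4 is expected to stay there too. The step that the limit leaves unreadable from compound 1 to compound 4 is expected to lie within the scatter, most likely with only a limit reported again. Compound 4 is estimated at 30000 nM, range 10000 nM to 100000 nM.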

Compound 4, half-maximal inhibitory concentration: > 20000 nM
Compound 4 was reported as a limit; the forecaster's own chance of this, stated with the estimate: 85%; the middle value is on the limit's open side.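

In this assay compound 4 gives > 20000 nM, a limit and not a number. Within the data shown here, compound 1 is also a limit, so no step between compound 1 and compound 4 can be read. The compounds shown leave open what ((prop-1-en-1-yl)carbonyl)methyl contributes in place of hydrogen.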